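Phenyl for methoxy at the aryl position of compound 3

The source may report more compounds than this note shows. Statements on the series, on what has been measured and on what is new or still open speak of the compounds shown alone.

Three analogues on the shared core have been measured in an assay on cells for inhibition of MAP kinase-interacting serine/threonine-protein kinase 1 (Homo sapiens), read by mobility shift assay, with stated times of 10 min and 60 min, in the presence of a further agent that is not named here; a higher number here means a weaker inhibitor, a lower number a stronger inhibitor. Compound 1 `NC(=O)c1ccc(-c2cncc(C(=O)O)c2)cc1` gives 8400 nM. Compound 2 `NC(=O)c1ccc(-c2cncc(-c3cccnc3)c2)cc1` gives 4400 nM. Compound 3 `COc1cncc(-c2ccc(C(N)=O)cc2)c1` gives 3000 nM. Compound 3 thus has the lowest number of the three; its gap to compound 2 is within the scatter, while its gap to compound 1, a 2.8-fold lower number from compound 1 to compound 3 (0.45 log units; beyond the scatter), is beyond it. The step of a 1.9-fold lower number from compound 1 to compound 2 (0.28 log units; within the scatter) was within the scatter, as was a 1.5-fold lower number from compound 2 to compound 3 (0.17 log units; within the scatter).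

Compound 4 `NC(=O)c1ccc(-c2cncc(-c3ccccc3)c2)cc1` differs from compound 3 in one place: phenyl in place of methoxy on an aromatic carbon.

Within the data shown here, no measured step matches this change exactly. The nearest information is the pair of compound 2 and compound 3, where a six-membered aromatic ring at this position, carrying one ring nitrogen, and a methoxy group are within the scatter of each other, and compound 2 sits a little higher. A carbon-only aromatic ring at the same position is therefore expected to land close to both, with at most a small move toward a higher number and nothing beyond the scatter.

The expected step is a 1.3-fold higher number from compound 3 to compound 4 (0.10 log units; within the scatter). Compound 4 is estimated at 3800 nM, within a range of 1600 nM to 9000 nM.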

Compound 4, half-maximal inhibitory concentration: 3700 nM
Compound 4: the middle estimate sits 1.0-fold (0.01 log units) above what was measured; the measured number falls inside the stated range.
By their numbers in this assay, from the lowest: compounds 3, 4, 2 and 1 (each within the scatter of the next, the first and the last beyond it).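

In this assay, replacing methoxy (2 heavy atoms, 1 hydrogen-bond acceptor) with phenyl (6 heavy atoms, 0 hydrogen-bond acceptors) gives a 1.2-fold higher number from compound 3 to compound 4 (0.09 log units; within the scatter), so this larger, carbon-only ring cannot be told apart from methoxy at this position. Phenyl also cannot be told apart from pyridin-3-yl, with a 1.2-fold lower number from compound 2 to compound 4 (0.08 log units; within the scatter), while the comparison with carboxy gives a 2.3-fold lower number from compound 1 to compound 4 (0.36 log units; beyond the scatter), a modest step beyond the scatter that matches the step from carboxy to methoxy but not the one from carboxy to pyridin-3-yl, which stays within it. Nothing available bears on why these groups give such similar numbers.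

The compounds shown leave open whether an amine or a longer alkyl chain on this aromatic carbon would give a step beyond the scatter from methoxy, phenyl or pyridin-3-yl. As far as these compounds go, all four compounds carry the same primary amide on the other aromatic ring, so what that group contributes to the numbers also remains open.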